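This account rests on a few compounds, and the source may have more. Where it says the series, first, only, none or still open, it means among the compounds named here.

Within the data shown here, compound 2 `O=C(Nc1ccc(Oc2ncnc3[nH]ncc23)cc1)Nc1ccc(C(F)(F)F)cc1` is the only compound here with a number rather than a limit in an assay on isolated protein for inhibition of vascular endothelial growth factor receptor 2 (Danio rerio), read by fluorescence and microscopy, with a stated time of 33 h; a higher number here means a weaker inhibitor, a lower number a stronger inhibitor: compound 2 gives 1200 nM. Compound 1 `O=C(Nc1ccc(Nc2ncnc3[nH]ncc23)cc1)Nc1ccc(C(F)(F)F)cc1` reaches only the limit of the assay, > 100000 nM. Compound 3 `Cn1ncc2c(Oc3ccc(NC(=O)Nc4ccc(C(F)(F)F)cc4)cc3)ncnc21` likewise shows only a limit, > 100000 nM. Both measured steps, an at least 83-fold lower number from compound 1 to compound 2 (1.92 log units; beyond the scatter) and an at least 83-fold higher number from compound 2 to compound 3 (1.92 log units; beyond the scatter), alter the shared core and involve (the limit of > 100000 nM in this assay, at which 2 of the 3 values shown sit). Compound 4 `O=C(NCC1CCCCC1)Nc1ccc(Oc2ncnc3[nH]ncc23)cc1` differs from compound 2 elsewhere: cyclohexylmethyl in place of 4-(trifluoromethyl)phenyl on an amide-type nitrogen. Neither measured step bears on this change, so no guidance about the size or direction of the step in this assay comes from them. Compound 4 is nevertheless expected to be the weaker inhibitor, estimated at 10000 nM with a range of 2000 nM to 100000 nM. This corresponds to an expected step of an 8.3-fold higher number from compound 2 to compound 4 (0.92 log units; beyond the scatter).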

Compound 4, half-maximal inhibitory concentration: > 100000 nM
Compound 4: a limit, no number; the forecaster's own chance of this, stated with the estimate: 35%; middle value at least 10-fold (1.00 log units) away from the limit.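

Replacing 4-(trifluoromethyl)phenyl with cyclohexylmethyl on the amide-type nitrogen gives an at least 83-fold higher number from compound 2 to compound 4 (1.92 log units; beyond the scatter) in this assay, so a change away from the shared core can also remove measurable inhibition. Compound 4 shows only a limit, > 100000 nM. The full size of this step therefore stays unknown: the limit of > 100000 nM in this assay, at which 3 of the 4 values shown sit.

The compounds shown leave open whether the loss follows from giving up the aromatic ring or the trifluoromethyl group. A plain phenyl or a 4-chlorophenyl on the same nitrogen would separate these two possibilities.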